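The source may hold more compounds than are shown below. What is called first, only, known or untested is meant among the compounds shown, and "the series" means these compounds.

Measured so far in a functional assay on MT4 cells (Homo sapiens) for cytotoxicity; a higher number here means that more compound is tolerated, a lower number that less compound is tolerated:
- compound 1 `Cc1cn([C@@H]2O[C@H](CO[Si](C)(C)C(C)(C)C)[C@@](C#N)(OS(C)(=O)=O)[C@H]2O[Si](C)(C)C(C)(C)C)c(=O)[nH]c1=O` gives 4.3 ug/mL
- compound 2 `CC(=O)Nc1ccn([C@@H]2O[C@H](CO[Si](C)(C)C(C)(C)C)[C@]3(OS(=O)(=O)C=C3N)[C@H]2O[Si](C)(C)C(C)(C)C)c(=O)n1` gives 7.1 ug/mL

Compound 2 at 7.1 ug/mL and compound 1 at 4.3 ug/mL lie within the scatter of each other, so compound 2 does not stand apart on these numbers. The next compound to be tested is compound 3 `CC(=O)Nc1ccn([C@@H]2O[C@H](CO[Si](C)(C)C(C)(C)C)[C@@]3(OS(=O)(=O)C=C3N)[C@H]2O[Si](C)(C)C(C)(C)C)c(=O)n1`, which comes from compound 2 through a single change: the two compounds have the same atoms and bonds and differ only in configuration as drawn: 1 of 4 stereo elements differ; a stereocentre at a saturated ring carbon is drawn S in compound 2 and R in compound 3 and no atom or bond is altered. Within the data shown here, no measured pair here isolates a change of configuration, so the data do not show what such a change does. The expected 1.1-fold lower number from compound 2 to compound 3 (0.04 log units; within the scatter) in this assay is therefore none beyond the scatter, with neither direction favoured. The estimated value for compound 3 is 6.5 ug/mL (expected range 2.5 ug/mL to 18 ug/mL).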

Compound 3, half-maximal cytotoxic concentration: 7.5 ug/mL
For compound 3 the middle estimate is 1.2-fold (0.06 log units) below the measured one; measured number inside the range.
By their numbers in this assay, from the lowest: compounds 1, 2 and 3 (each within the scatter of the next).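

The pair gives the first measured case in this assay of a change of configuration alone, and at this saturated ring carbon it amounts to a 1.1-fold higher number from compound 2 to compound 3 (0.02 log units; within the scatter) and so stays within the scatter. Drawing this stereocentre R rather than S therefore leaves no difference that this assay can resolve, and the comparison isolates that one feature: the fact that compounds 2 and 3 differ only in the configuration as drawn. The reading applies to this single stereocentre on the shared core and says nothing about the other three stereo elements.

Going by these compounds, whether the two configurations would stay as close in this assay with free hydroxyl groups in place of the tert-butyldimethylsilyl groups remains open. So does the question of whether they would stay as close with a carboxylic acid in place of the amine.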